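Extending the side chain with an ether oxygen

A few compounds are considered here, and "the series" means these few. Any claim that something is new, unique, unknown or untested is made for them only; others in the source may bear on it.

Measured compounds:
Compound 1, `CCC(Nc1nnc(-c2ccc(OC)cc2)o1)[C@H]1CC[C@@H](c2ccnc3ccc(C(F)(F)F)cc32)CC1`: 3 nM
Compound 2, `C[C@@H](c1ncc(-c2ccc(Cl)cc2)[nH]1)[C@H]1CC[C@@H](c2ccnc3ccc(F)cc32)CC1`: 11 nM

Both compounds were tested in an assay on tissue (HeLa cells) for inhibition of Indoleamine 2,3-dioxygenase 1 (Homo sapiens), read by fluorescence, with a stated time of 18 h; a higher number here means a weaker inhibitor, a lower number a stronger inhibitor. Compound 1 gives 3 nM, the lowest of the two numbers, and compound 2 gives 11 nM, a difference that lies beyond the usual scatter of repeated measurements. The two compounds differ in several places at once, so their values alone say nothing about any single change.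

Compound 3, `CCOCC(Nc1nnc(-c2ccc(OC)cc2)o1)[C@H]1CC[C@@H](c2ccnc3ccc(C(F)(F)F)cc32)CC1`, has not yet been measured. It differs from compound 1 by ethoxy in place of methyl on a saturated chain carbon, two bonds along the chain from a nitrogen on an aromatic ring and a saturated ring carbon. Within the data shown here, no measured pair shows this change, so its effect is unknown. The change is small and sits away from the aromatic parts of the shared core, so the expectation is a step in this assay of no clear direction, likely within the scatter or at most a modest weakening. Compound 3 is therefore estimated at 5 nM, with a range from 1.5 nM to 20 nM, a step from compound 1 to compound 3 of a 1.7-fold higher number from compound 1 to compound 3 (0.22 log units; within the scatter).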

Compound 3, half-maximal inhibitory concentration: 13 nM
Compound 3: the middle estimate sits 2.6-fold (0.41 log units) below what was measured, and the stated range covers the measured number.
By their numbers in this assay, from the lowest: compound 1; then compounds 2 and 3 (each within the scatter of the next).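

This position on the saturated chain carbon responds to its substituent: in this assay, ethoxy in place of methyl gives a 4.3-fold higher number from compound 1 to compound 3 (0.64 log units; beyond the scatter). The change is modest, and compound 3 still gives 13 nM, so this position accepts a chain with an ether oxygen at a measurable but limited cost. Nothing shown here accounts for this loss of potency.

The swap adds chain length and a hydrogen-bond acceptor together, so this single step cannot show which of the two matters. A plain butyl chain in place of the ethoxymethyl would separate those two contributions, while an amine or a carboxylic acid at the end of the chain would show how far this position tolerates other kinds of group.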